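This account rests on a few compounds, and the source may have more. Where it says the series, first, only, none or still open, it means among the compounds named here.

Compound 1, `Cc1nccn1-c1cnc(NCc2c(F)ccc3c2CCO3)c2cn[nH]c(=O)c12`, compound 2, `C[C@@H]1CC(=O)N(c2cnc(NCc3c(F)ccc4c3CCO4)n3cnnc23)C1`, and compound 3, `O=C(Nc1cnc(NCc2c(F)ccc3c2CCO3)n2cnnc12)c1cccnc1`, have each been measured in a physicochemical assay for lipophilicity, using the shake flask method, in phosphate buffer, measured as octanol-water partition, with a stated time of 30 min, at pH 7.4; on this read-out higher numbers stand for higher lipophilicity and lower numbers for lower lipophilicity. Compound 1 gives 2.1, compound 2 gives 1.8, and compound 3 gives 2. Compound 1 thus has the highest of the three numbers, but its distances to compound 3 and to compound 2 both lie within the scatter, so the three cannot truly be ranked. Within the data shown here, the only step between measured compounds that differ in a single place, a number 0.20 log units higher from compound 2 to compound 3 (within the scatter), also stays within the scatter.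

Compound 4, `CNC(=O)c1ncc(-c2cnc(NCc3c(F)ccc4c3CCO4)c3cn[nH]c(=O)c23)n1C`, has not yet been measured in this assay. It differs from compound 1 in one place: 1-methyl-2-(methylcarbamoyl)-1H-imidazol-5-yl in place of 2-methyl-1H-imidazol-1-yl on an aromatic carbon. Among the measured compounds shown here, no measured step exchanges these two groups on this core, so there is no direct guide. For the measured compounds named here, the one step that exists, which brings in a ((pyridin-3-yl)carbonyl)amino group on a different core, hardly moved the number, and that is the closest hint available. The expectation is therefore a small shift downward or none beyond the scatter, expressed as a number 0.30 log units lower from compound 1 to compound 4 (within the scatter). Compound 4 is estimated at 1.8, with a likely range from 1.3 to 2.3.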

Compound 4, distribution coefficient: 2.5
The estimate for compound 4 lay 0.70 log units below the measured number, outside the stated range (above it).
By their numbers in this assay, from the lowest: compounds 2, 3 and 1 (each within the scatter of the next); then compound 4.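

In this assay, the aromatic carbon that carries the imidazole group on the core of compound 1 turns out to be a place where a change can shift the number: a number 0.40 log units higher from compound 1 to compound 4 (beyond the scatter) is a modest step, but the only one in this set that lies beyond the scatter. The step goes upward even though the entering 1-methyl-2-(methylcarbamoyl)-1H-imidazol-5-yl, with 10 heavy atoms, is larger than the leaving 2-methyl-1H-imidazol-1-yl, with 6, and carries a hydrogen-bond donor that the leaving group lacks, so in this one pair those counts did not point to a lower number. Nothing measured here explains the rise, and the exchange alters the size of the group, adds the amide and changes how the imidazole is attached, all in one step.

Which of these alterations accounts for the step stays open, and a plain 1-methyl-1H-imidazol-5-yl group at this place would be needed to separate the methylcarbamoyl part from the change of attachment. As far as these compounds go, how far the number moves with a carboxylic acid or an amine on this carbon also remains unknown from these compounds.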